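The source may hold more compounds than are shown below. What is called first, only, known or untested is meant among the compounds shown, and "the series" means these compounds.

Working notes on a small chalcone series. Compound 1 `COc1cc(-c2cc(/C=C/C(=O)c3ccc(N)cc3)[nH]n2)cc(OC)c1OC`, compound 2 `COc1ccc(C(=O)/C=C/c2cc(-c3cc(OC)c(OC)c(OC)c3)n[nH]2)cc1OC` and compound 3 `COc1ccc(C(=O)/C=C/c2cc(-c3cc(OC)c(OC)c(OC)c3)n[nH]2)cc1` are measured; compound 4 `COc1ccc(-c2cc(/C=C/C(=O)c3ccc(N)cc3)[nH]n2)cc1OC` is not yet.

In a functional assay on SK-OV-3 cells (Homo sapiens) for cytotoxicity, read by sulforhodamine B assay, with a stated time of 48 h, tested at 10 uM (on this read-out lower numbers stand for a stronger effect and higher numbers for a weaker effect at the one concentration tested), compound 1 gives -9%. In this assay compound 2 gives -12%, and compound 3 gives 18%.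

The two cores differ by 4-aminophenyl in place of 3,4-dimethoxyphenyl on a carbonyl carbon, and the corresponding step of a number 3 percentage points lower from compound 1 to compound 2 (within the scatter) lies within the scatter. Replacing amino by methoxy on the aromatic carbon gives the step of a number 27 percentage points higher from compound 1 to compound 3 (beyond the scatter). The change hydrogen in place of methoxy on an aromatic carbon gives the step of a number 30 percentage points higher from compound 2 to compound 3 (beyond the scatter), a modest weakening at the single concentration.

Compound 4 differs from compound 1 by hydrogen in place of methoxy on an aromatic carbon. This is the same kind of change as from compound 2 to compound 3, not the same change: in compound 1 the aromatic carbon carrying the methoxy is in addition meta to a methoxy group (2 heavy atoms), whereas in compound 2 it is only ortho to a methoxy group and meta to a large group. Among the measured compounds shown here, the step of a number 30 percentage points higher from compound 2 to compound 3 (beyond the scatter) is the only measured instance of this change and is the basis of the expectation for compound 4. The expected step is a number 27 percentage points higher from compound 1 to compound 4 (beyond the scatter). For compound 4 the estimate in this assay is 18%, expected to fall between 0% and 38%.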

Compound 4, a percentage reported as activity, at one concentration (the size of the read-out at that concentration, not a potency): 29%
Compound 4: middle estimate off by 11 percentage points, on the low side; the range from low to high includes it.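

Hydrogen in place of methoxy on an aromatic carbon again weakens the read-out in this assay, and the new step is a number 38 percentage points higher from compound 1 to compound 4 (beyond the scatter). Set beside the earlier step, it shows no difference in size beyond what repeated measurement allows: the same change on two cores in this assay, a number 30 percentage points higher (beyond the scatter) from compound 2 to compound 3 and a number 38 percentage points higher (beyond the scatter) from compound 1 to compound 4, 8 percentage points apart, within the scatter of two such steps The change therefore carries over in direction and, within the scatter, in size between these two cores, even though on the core of compound 1 the carbon is also meta to a methoxy group, but two pairs at the one concentration tested make no general rule, and they say nothing about potency or about why the read-out moves.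

The compounds shown leave open what happens at this aromatic carbon with something other than methoxy or hydrogen, such as a hydroxy group, a fluorine atom or a longer ethoxy chain, and so whether the methoxy group itself matters or any group there would do. Also open, from the compounds shown here alone, is whether the step keeps its size when the amino group on the core of compound 1 gives way to a carboxylic acid or an acetamide.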